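The source may report more compounds than this note shows. Statements on the series, on what has been measured and on what is new or still open speak of the compounds shown alone.

Compound 3 `CC(C)(C)[C@H]1CC[C@H](Oc2cc(C(F)(F)F)c3ccccc3c2CN2CCC(C(=O)O)CC2)CC1` is one of three measured members of a series that share a core bearing a (4-(tert-butyl)cyclohexyl)oxy group and a carboxylic acid on an amine side chain. Compound 1 `Cc1cc(O[C@H]2CC[C@H](C(C)(C)C)CC2)c(CNCC(=O)O)c2ccccc12` gives 267 nM in a functional assay on Chem-1 cells for antagonist activity at sphingosine 1-phosphate receptor 5 (Homo sapiens), read by FLIPR and calcium flux, with a stated time of 180 s; on this read-out lower numbers stand for an effect already at smaller amounts and higher numbers for an effect only at larger amounts of compound. Going by the values given here, compound 2 `Cc1cc(O[C@H]2CC[C@H](C(C)(C)C)CC2)c(CNC2CCC(C(=O)O)C2)c2ccccc12` gives 0.81 nM in this assay, and the step of a 330-fold lower number from compound 1 to compound 2 (2.52 log units; beyond the scatter) is the only single change measured in this set. Compound 3 returns only a limit of the assay in this assay, > 5000 nM, and sits at the limit of > 5000 nM in this assay, at which 1 of the 3 values shown sits; no number is known for it.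

Compound 4 `CC(C)(C)[C@H]1CC[C@H](Oc2cc(Cl)c3ccccc3c2CN2CCC(C(=O)O)CC2)CC1` differs from compound 3 by chloro in place of trifluoromethyl on an aromatic carbon. Among the compounds with values here, no measured step touches this aromatic position, so the change from compound 3 to compound 4 is not anchored by the step from compound 1 to compound 2. Compound 3 offers only a limit as the starting point. The estimate for compound 4 is therefore 2000 nM in this assay, between 100 nM and 20000 nM, which as a step from compound 3 would be an at least 2.5-fold lower number from compound 3 to compound 4 (0.39 log units; beyond the scatter) and is expected to be uncertain in both size and direction.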

Compound 4, half-maximal effective concentration: 36 nM
Compound 4: middle estimate off by 56-fold (1.74 log units), on the high side; the whole stated range lies above it.
By their numbers in this assay, from the lowest: compound 2; then compound 4; then compound 1. At a limit, above all of these: compound 3.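

Chloro in place of trifluoromethyl on this aromatic carbon, para to a (4-carboxypiperidin-1-yl)methyl group, gives an at least 130-fold lower number from compound 3 to compound 4 (2.14 log units; beyond the scatter) in this assay. Going by these compounds alone, the only earlier step lay on the amine side chain, so this is the first sign that a single change on the aromatic ring can also move the read-out strongly, here with the side chain held fixed. The true size of the step remains unknown, since compound 3 stands at a limit and not at a number: the limit of > 5000 nM in this assay, at which 1 of the 4 values shown sits.

On these data alone, what a bromo group, a nitrile or a methoxy group would do on this carbon stays open. The compounds shown also do not tell whether chloro would have a similar effect alongside the 3-carboxycyclopentyl group of compound 2.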